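The source may hold more compounds than are shown below. What is called first, only, known or untested is meant among the compounds shown, and "the series" means these compounds.

Compound 1 `Fc1cccc(-c2nc(Nc3ccc(Cl)cc3)c3cc(F)ccc3n2)c1` is the anchor of this set. In a functional assay on HL-60 cells (Homo sapiens) for cytotoxicity, read by MTT assay, with a stated time of 48 h (on this read-out lower numbers stand for stronger inhibition and higher numbers for weaker inhibition), compound 1 gives 45700 nM, the highest of the two numbers available. Its nearest neighbour is compound 3 `Oc1ccccc1Nc1nc(-c2cccc(F)c2)nc2ccc(F)cc12`, which in this assay gives 44400 nM, a step of a 1.0-fold lower number from compound 1 to compound 3 (0.01 log units; within the scatter). Compound 2 `Fc1cccc(-c2nc(Nc3ccccc3Br)c3cc(F)ccc3n2)c1` gives only a limit in this assay, > 50000 nM. Both measured changes of the aryl group on the ring nitrogen, an at least 1.0-fold higher number from compound 1 to compound 2 (0.03 log units; that floor lies within the scatter) and a 1.0-fold lower number from compound 1 to compound 3 (0.01 log units; within the scatter), stay within the scatter.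

Compound 4 `Cc1ccccc1Nc1nc(-c2cccc(F)c2)nc2ccc(F)cc12` is not yet measured. It differs from compound 1 as follows: 2-methylphenyl in place of 4-chlorophenyl on a nitrogen on an aromatic ring. Since the two comparable swaps moved nothing beyond the scatter, no step beyond the scatter is expected in this assay; the expected change is a 1.0-fold lower number from compound 1 to compound 4 (0.01 log units; within the scatter). Compound 4 is estimated at 45000 nM, within 22000 nM to 90000 nM.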

Compound 4, half-maximal inhibitory concentration: > 50000 nM
Compound 4 ended at the assay's limit; the forecaster's own chance of this, stated with the estimate: 40%; middle value at least 1.1-fold (0.04 log units) away from the limit.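

Compound 4 gives only a limit in this assay, the second such result in this set: the limit of > 50000 nM in this assay, at which 2 of the 4 values shown sit. As far as these compounds go, the two readable steps, an at least 1.0-fold higher number from compound 1 to compound 4 (0.03 log units; that floor lies within the scatter) and an at least 1.1-fold higher number from compound 3 to compound 4 (0.05 log units; that floor lies within the scatter), give floors only, so 2-methylphenyl on this nitrogen shows no change beyond the scatter, while the true size of either step remains unknown. The step between the two limits cannot be read.

From the compounds shown here alone, how far compound 4 lies past its limit remains open. So does how an amine or a carboxylic acid on this aromatic ring would read.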